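The source may report more compounds than this note shows. Statements on the series, on what has been measured and on what is new or still open speak of the compounds shown alone.

Measured compounds in a functional assay on the whole organism for inhibition, with Rattus norvegicus as the target, read by paw edema; a lower number here means that less compound is needed, a higher number that more compound is needed for the effect:
- compound 1, `O=C(O)c1cc(-c2ncco2)ccc1O`: compound 1 gives 100 mg/kg
- compound 2, `O=C(O)c1cc(-c2cscn2)ccc1O`: compound 2 gives 95 mg/kg
- compound 3, `O=C(O)c1cc(-n2ccnn2)ccc1O`: compound 3 gives 150 mg/kg

Compound 3 holds the highest of the three numbers, but its distance to either neighbour stays inside the scatter: a 1.5-fold higher number from compound 1 to compound 3 (0.18 log units; within the scatter) and a 1.6-fold higher number from compound 2 to compound 3 (0.20 log units; within the scatter) are both small, and a 1.1-fold lower number from compound 1 to compound 2 (0.02 log units; within the scatter) is smaller still. So far every exchange of the five-membered ring on the shared core has left this assay unmoved beyond the usual spread.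

Compound 4, `O=C(O)c1cc(-c2ncc[nH]2)ccc1O`, differs from compound 3 in one place: 1H-imidazol-2-yl in place of 1H-1,2,3-triazol-1-yl on an aromatic carbon. This is again an exchange of one five-membered aromatic ring for another at the same position, the kind of change covered by the three measured steps, each of which lay within the scatter. Nothing in the set points to a direction; a step of no more than the scatter is expected for a 1.3-fold lower number from compound 3 to compound 4 (0.10 log units; within the scatter). The number for compound 4 in this assay is therefore estimated at 120 mg/kg, with a plausible range from 60 mg/kg to 250 mg/kg.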

Compound 4, dose for half-maximal effect: 200 mg/kg
Compound 4: the middle estimate sits 1.7-fold (0.22 log units) below what was measured, and the stated range covers the measured number.
By their numbers in this assay, from the lowest: compounds 2, 1, 3 and 4 (each within the scatter of the next, the first and the last beyond it).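

In this assay, the change to 1H-imidazol-2-yl gives the only step among these compounds that lies beyond the scatter at this position, on the aromatic carbon para to a hydroxy group and meta to a carboxy group: a 2.1-fold higher number from compound 2 to compound 4 (0.32 log units; beyond the scatter), which is modest. The other two steps to compound 4, a 1.3-fold higher number from compound 3 to compound 4 (0.12 log units; within the scatter) and a 2.0-fold higher number from compound 1 to compound 4 (0.30 log units; within the scatter), remain within the scatter, so the separation holds only against the 1,3-thiazol-4-yl group of compound 2 and does not amount to a distinct effect of 1H-imidazol-2-yl across the series. No measurement at hand accounts for this one step.

All four groups at this position are five-membered aromatic rings, which leaves open how an open-chain group such as an amine, a carboxylic acid or a longer alkyl chain would read in this assay. Also open, from the compounds shown here alone, is whether a methyl group on the ring nitrogen of 1H-imidazol-2-yl, or a six-membered pyridine ring in its place, would carry the number further from that of compound 2 or bring it back.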